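The source may report more compounds than this note shows. Statements on the series, on what has been measured and on what is new or still open speak of the compounds shown alone.

The compounds measured so far:
compound 1, `Cc1cccc(/C(N)=N/NC(=S)N2CCSCC2)n1`, giving 47.2% in a functional assay on A-375 cells (Homo sapiens) for cytotoxicity, read by MTT assay, with a stated time of 72 h, tested at 1 uM; a lower number here means less inhibition of growth, a higher number more inhibition of growth at the concentration tested
compound 2, `N/C(=N\NC(=S)N1CCSCC1)c1ccccn1`, giving 34% in this assay
compound 3, `Cc1cccc(/C(N)=N/NC(=S)N2CCCC2)n1`, giving 13.6% in this assay

Compound 3 stands lowest of the three; its nearest neighbour is compound 2, and the gap to compound 1 is the step of a number 33.6 percentage points lower from compound 1 to compound 3 (beyond the scatter). That step rests on one structural change, (pyrrolidin-1-yl in place of thiomorpholin-4-yl on a thiocarbonyl carbon).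

For the measured compounds named here, the change of interest is the one from compound 1 to compound 2, (hydrogen in place of methyl on an aromatic carbon), which gave a number 13.2 percentage points lower from compound 1 to compound 2 (beyond the scatter). The same change returns between compound 3 and compound 4, `N/C(=N\NC(=S)N1CCCC1)c1ccccn1`, which has not yet been tested in this assay. This is hydrogen in place of methyl on an aromatic carbon, and the place is the same word for word as before: on an aromatic carbon of a six-membered aromatic ring with 1 nitrogen, next to the ring nitrogen, meta to a large group. The two cores differ as described by pyrrolidin-1-yl in place of thiomorpholin-4-yl on a thiocarbonyl carbon.

Going by the values given here, with only one earlier instance of the change to rest on, compound 4 is expected to sit lower than compound 3, by a step estimated as a number 9.6 percentage points lower from compound 3 to compound 4 (within the scatter) in this assay, roughly like the earlier one, because the earlier instance gave a number 13.2 percentage points lower from compound 1 to compound 2 (beyond the scatter). Since compound 3 already starts at 13.6%, the room downward is small, and compound 4 is expected to show little or no growth inhibition. The estimate for compound 4 in this assay is 4%, with a range from -8% to 18%.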

Compound 4, percent growth inhibition at one concentration: 65.7%
Beside the measured number, compound 4's estimate is 61.7 percentage points below it, outside the stated range (above it).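

In this assay, hydrogen in place of methyl on an aromatic carbon gave a number 52.1 percentage points higher from compound 3 to compound 4 (beyond the scatter), so the change did not carry over in sign or size from the thiomorpholin-4-yl compounds to the pyrrolidin-1-yl compounds: the same change on two cores in this assay, a number 13.2 percentage points lower (beyond the scatter) from compound 1 to compound 2 and a number 52.1 percentage points higher (beyond the scatter) from compound 3 to compound 4, 65.3 percentage points apart, beyond the scatter of two such steps

Seen from the other side of the same four compounds, pyrrolidin-1-yl in place of thiomorpholin-4-yl on a thiocarbonyl carbon gave a number 31.7 percentage points higher from compound 2 to compound 4 (beyond the scatter), a step in the opposite direction to the one seen with methyl on the ring: the same change on two cores in this assay, a number 33.6 percentage points lower (beyond the scatter) from compound 1 to compound 3 and a number 31.7 percentage points higher (beyond the scatter) from compound 2 to compound 4, 65.3 percentage points apart, beyond the scatter of two such steps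

Within this set, then, the step for either change depends on what stands at the other place, and a step measured on one core cannot be carried to the other; this does not show why the two places are coupled, nor how general the reversal is, since it rests on one square of four compounds read at one concentration in one cell line.

Going by these compounds, it remains open whether other groups on that aromatic carbon, such as ethyl or methoxy, would follow the methyl or the hydrogen compounds. On these data alone, it is equally open how an open-chain dimethylamino group on the thiocarbonyl carbon would behave in place of either ring.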